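Propylcarbamoyl in Place of Fluoro on the Shared Core

The compounds below may be only part of what the source reports. "The series", "measured", "known", "first", "only" and "open" are said of these compounds alone.

Compound 1, `CCC1C(=O)N(C)c2cnc(-n3ccc4cc(C(=O)NC)ccc43)nc2N1c1ccn(C)n1`: 218 nM
Compound 2, `CCC1C(=O)N(C)c2cnc(-n3ccc4cc(F)ccc43)nc2N1c1ccn(C)n1`: 1500 nM

In an assay for inhibition of serine/threonine-protein kinase PLK2 (Homo sapiens), read by FRET and Z'-LYTE, with a stated time of 1 h (on this read-out lower numbers stand for stronger inhibition and higher numbers for weaker inhibition), compound 2 gives 1500 nM, the highest of the two numbers recorded so far. Its nearest neighbour is compound 1, which gives 218 nM. Compound 3, `CCCNC(=O)c1ccc2c(ccn2-c2ncc3c(n2)N(c2ccn(C)n2)C(CC)C(=O)N3C)c1`, has not yet been tested. It differs from compound 2 in a single place: propylcarbamoyl in place of fluoro on an aromatic carbon. For the measured compounds named here, only one measured step bears on this change, and it runs in the opposite direction: a 6.9-fold higher number from compound 1 to compound 2 (0.84 log units; beyond the scatter). Compound 3 puts a carbamoyl group back at the position where compound 2 carries fluoro, with a propyl chain instead of the methyl chain of compound 1. A fall in the number of about the same size as that earlier rise is therefore expected, bringing compound 3 close to compound 1, though the longer chain leaves some uncertainty. The expected step is a 5.0-fold lower number from compound 2 to compound 3 (0.70 log units; beyond the scatter). Compound 3 is estimated at 300 nM, with a range from 100 nM to 900 nM.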

Compound 3, half-maximal inhibitory concentration: 207 nM
Beside the measured number, compound 3's estimate is 1.4-fold (0.16 log units) above it; the range from low to high includes it.
By their numbers in this assay, from the lowest: compounds 3 and 1 (each within the scatter of the next); then compound 2.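

In this assay, propylcarbamoyl in place of fluoro on this aromatic carbon gives a 7.2-fold lower number from compound 2 to compound 3 (0.86 log units; beyond the scatter) and so shows that the methyl chain of compound 1 is not the only amide chain tolerated here. Compound 1 and compound 3 cannot be told apart, with ethyl in place of hydrogen on a saturated chain carbon bound to an amide-type nitrogen giving a 1.1-fold lower number from compound 1 to compound 3 (0.02 log units; within the scatter) in this comparison. Set beside a 6.9-fold higher number from compound 1 to compound 2 (0.84 log units; beyond the scatter) from the earlier pair, this means that both amide-bearing compounds, and not just one, give clearly lower numbers than the fluoro compound on the shared core.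

Still open, on these data alone, is whether a longer chain on the amide nitrogen, a cyclopropyl group there, or an amine or a carboxylic acid on this aromatic carbon would keep the number at this level. The data shown also offer no explanation for the difference between the amides and fluoro.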